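Trifluoromethoxy for fluoro: does the gain repeat?

The compounds below may be only part of what the source reports. "The series", "measured", "known", "first", "only" and "open" are said of these compounds alone.

Compound 1 `Cc1ccc2c(=O)[nH]c(-c3ccccc3OC(F)(F)F)nc2c1` gives 100% in an assay on isolated protein for inhibition of DNA topoisomerase 1 (Homo sapiens), with a stated time of 30 min, tested at 100 uM; a higher number here means a stronger effect of the compound at the concentration tested, a lower number a weaker effect. Compound 2 `Cc1ccc2c(=O)[nH]c(-c3ccccc3F)nc2c1` gives 81.2%. Compound 3 `Cc1ccc2nc(-c3cccc(F)c3)[nH]c(=O)c2c1` gives 82.9%.

Compound 2 and compound 3 are built from the same atoms joined differently; the difference between the two cores is not broken down here, and their values lie within the scatter of each other. Between compound 2 and compound 1 one change is made, (trifluoromethoxy in place of fluoro on an aromatic carbon), sitting ortho to a large group, and it brought a number 18.8 percentage points higher from compound 2 to compound 1 (beyond the scatter). Compound 4 `Cc1ccc2nc(-c3cccc(OC(F)(F)F)c3)[nH]c(=O)c2c1` carries the same kind of change relative to compound 3, (trifluoromethoxy in place of fluoro on an aromatic carbon), but here the place is meta to a large group. Compound 4 is therefore expected to rise by about a number 13.1 percentage points higher from compound 3 to compound 4 (beyond the scatter), resting on the gain seen as a number 18.8 percentage points higher from compound 2 to compound 1 (beyond the scatter), giving an estimate of 96% for compound 4, between 84% and 100%.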

Compound 4, a percentage reported as inhibition, at one concentration (the size of the read-out at that concentration, not a potency): 98.6%
The estimate for compound 4 lay 2.6 percentage points below the measured number, and the stated range covers the measured number.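

In this assay, trifluoromethoxy in place of fluoro brought a number 15.7 percentage points higher from compound 3 to compound 4 (beyond the scatter), so the gain seen on the core of compound 2 also appears on the core of compound 3. The two gains match in size: the same change on two cores in this assay, a number 18.8 percentage points higher (beyond the scatter) from compound 2 to compound 1 and a number 15.7 percentage points higher (beyond the scatter) from compound 3 to compound 4, 3.1 percentage points apart, within the scatter of two such steps. Among the compounds shown here, this rests on only two pairs, which differ in both core and the place of the group, so the influence of core and place cannot be told apart, and a reading at one concentration says nothing about potency.

Still open, as far as these compounds go, is whether the gain carries over to further cores. Also open, from the compounds shown here alone, is how other groups at the same place, such as an amine or a carboxylic acid, would compare with trifluoromethoxy.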